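The compounds below may be only part of what the source reports. "The series", "measured", "known", "first", "only" and "open" are said of these compounds alone.

Measured compounds:
compound 1 `CC(C)Cc1csc(N)c1C(=O)c1ccc(Cl)cc1` gives 1%
compound 2 `CC(C)(C)c1csc(N)c1C(=O)c1ccc(Cl)cc1` gives 1%
compound 3 `CC(C)(C)Cc1csc(N)c1C(=O)c1ccc(Cl)cc1` gives 1%

All three values come from an assay on CHO cells for displacement of a labelled ligand from adenosine receptor A1 (Homo sapiens), read by scintillation counting, tested at 10 uM; on this read-out higher numbers stand for more inhibition at the one concentration tested (going by the name of the read-out) and lower numbers for less inhibition. Compound 3 sits level with compounds 1 and 2 at the digits shown: the steps of no change at the digits printed from compound 1 to compound 2 (within the scatter), no change at the digits printed from compound 1 to compound 3 (within the scatter) and no change at the digits printed from compound 2 to compound 3 (within the scatter) all stay within the scatter, so varying the saturated chain on the shared core leaves this read-out essentially at zero. Compound 4 `CC(C)(C)Cc1c(-c2ccoc2)sc(N)c1C(=O)c1ccc(Cl)cc1` differs from compound 3 by furan-3-yl in place of hydrogen on an aromatic carbon. For the measured compounds named here, none of the measured steps involves a furan-3-yl or a change on an aromatic carbon, so none bears directly on this change; the measured compounds only show that the shared core itself gives almost no inhibition. Compound 4 is therefore expected to give about 5% in this assay, within -10% to 35%, the expected step being a number 4 percentage points higher from compound 3 to compound 4 (within the scatter).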

Compound 4, a percentage reported as inhibition, at one concentration (the size of the read-out at that concentration, not a potency): 1%
Estimate against measurement, compound 4: 4 percentage points above; the range from low to high includes it.
By their numbers in this assay, from the lowest: compounds 1, 2, 3 and 4 (each within the scatter of the next).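

Placing furan-3-yl instead of hydrogen on the aromatic carbon next to the ring sulfur adds a five-membered aromatic ring at this position, yet this assay shows no change at the digits printed from compound 3 to compound 4 (within the scatter). For the compounds shown here, this is the first change at this position, and inhibition stays as close to zero as it was for the shared core. No measurement here accounts for this flat result. Going by these compounds, whether an amine, a carboxylic acid or a longer chain on this same carbon would give a higher reading remains open.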